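This account rests on a few compounds, and the source may have more. Where it says the series, first, only, none or still open, it means among the compounds named here.

Going by the values given here, compound 2 `COc1ccccc1CN(C)Cc1ccc(/C=C2\Oc3cc(OC)c(OC)cc3C2=O)cc1O` gives 8.4% in an assay on cells for inhibition of Amine oxidase [flavin-containing] B (Homo sapiens), read by fluorescence, with a stated time of 30 min, tested at 10 uM (a higher number here means more inhibition at the concentration tested (going by the name of the read-out), a lower number less inhibition), the lower of the two numbers measured so far. Compound 1 `COc1cc2c(cc1OC)C(=O)/C(=C/c1ccc(CN3CCCCC3)c(O)c1)O2` gives 32%. Compound 3 `CCN(CC)Cc1ccc(/C=C2\Oc3cc(OC)c(OC)cc3C2=O)cc1O` differs from compound 2 in one place: diethylamino in place of (2-methoxybenzyl)(methyl)amino on a saturated chain carbon bound to an aromatic carbon. Among the compounds with values here, the only step that bears on this is a number 23.6 percentage points lower from compound 1 to compound 2 (beyond the scatter), where a large amine replaced a small cyclic one. Compound 3 carries a small amine again, so a rise beyond the scatter is expected, as the step from compound 2 to compound 3 is estimated at a number 16.6 percentage points higher from compound 2 to compound 3 (beyond the scatter). Compound 3 is therefore expected to give 25%, in a range from 8% to 42%.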

Compound 3, a percentage reported as inhibition, at one concentration (the size of the read-out at that concentration, not a potency): 7.2%
Compound 3: the middle estimate sits 17.8 percentage points above what was measured, and the stated range ends above it.
By their numbers in this assay, from the lowest: compounds 3 and 2 (each within the scatter of the next); then compound 1.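

In this assay there is a number 1.2 percentage points lower from compound 2 to compound 3 (within the scatter) and so a much smaller open-chain amine on this saturated chain carbon does not bring the number back up. There is also a number 24.8 percentage points lower from compound 1 to compound 3 (beyond the scatter) and so, among these three compounds, only the ring amine piperidin-1-yl stands apart from the other two. Nothing measured here explains that gap. On these data alone, whether another ring amine, such as pyrrolidine or morpholine, would stay near compound 1 remains open. So does whether the ring itself matters, or whether dimethylamino would behave like diethylamino.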